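The source may report more compounds than this note shows. Statements on the series, on what has been measured and on what is new or still open speak of the compounds shown alone.

In a physicochemical assay for solubility, read by HPLC, in phosphate buffer, at pH 6.5 (a higher number here means a more soluble compound, a lower number a less soluble compound), compound 3 `COC(=O)C1=C(CN2CCCCC2)NC(c2nccs2)=NC1(C)c1ccc(F)cc1` gives 282 ug/mL. Compound 2 `COC(=O)C1=C(C)NC(c2nccs2)=NC1(C)c1ccc(S(C)(=O)=O)cc1` gives 365 ug/mL in this assay, and compound 1 `COC(=O)C1=C(C)NC(c2nccs2)=N[C@]1(C)c1ccc(F)cc1` gives 178 ug/mL. Compound 3 thus stands second highest of the three numbers, nearest to compound 2 and furthest from compound 1, with both gaps within the scatter. Compound 4 `COC(=O)C1=C(COC2CCOC2)NC(c2nccs2)=NC1(C)c1ccc(F)cc1` is not yet measured in this assay. It differs from compound 3 in one place: (oxolan-3-yl)oxy in place of piperidin-1-yl on a saturated chain carbon bound to a double-bonded ring carbon. Going by the values given here, no step between measured compounds matches this change, so there is nothing to set its size against. The step of a 1.6-fold lower number from compound 3 to compound 4 (0.19 log units; within the scatter) is expected to be a small one, downward if it is beyond the scatter at all. Compound 4 is estimated to give 180 ug/mL in this assay, within a range of 70 ug/mL to 400 ug/mL.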

Compound 4, solubility: 30 ug/mL
Beside the measured number, compound 4's estimate is 6.0-fold (0.78 log units) above it; measured number outside the range, below it.
By their numbers in this assay, from the lowest: compound 4; then compounds 1, 3 and 2 (each within the scatter of the next, the first and the last beyond it).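

In this assay, (oxolan-3-yl)oxy in place of piperidin-1-yl on a saturated chain carbon bound to a double-bonded ring carbon brings a 9.4-fold lower number from compound 3 to compound 4 (0.97 log units; beyond the scatter), although both groups hold the same count of heavy atoms. Going by these compounds alone, this is the first measure of a change at this position, and it shows that the number is sensitive to which group sits there. Nothing at hand accounts for the size of this step. This single pair leaves open whether the nitrogen or the ring as a whole sets the number. Morpholin-4-yl or a plain methoxy group on the same carbon would separate the two.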